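Benzyl for benzylcarbamoyl on the ring amine of compound 1

This account rests on a few compounds, and the source may have more. Where it says the series, first, only, none or still open, it means among the compounds named here.

Among the measured compounds shown here, compound 1 `COc1ccc(-c2cnc3nc(N)nc(N4CCN(C(=O)NCc5ccccc5)CC4)c3n2)cc1OC` is the only member of the set with a numerical result: in a functional assay on cells (T-cell, Homo sapiens) for inhibition (on this read-out higher numbers stand for weaker inhibition and lower numbers for stronger inhibition), compound 1 gives 18 nM. Compound 2 `CC(C)Oc1nc(N)nc2ncc(-c3ccc(C#N)cc3)nc12`, built on a different core, is reported in this assay only as a limit, > 10000 nM, and not as a number. For the measured compounds named here, no single-point step links compound 1 and compound 2, so their two values say only that one compound inhibits measurably and the other sits at the limit of > 10000 nM in this assay, at which 1 of the 2 values shown sits.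

The next compound, compound 3 `COc1ccc(-c2cnc3nc(N)nc(N4CCN(Cc5ccccc5)CC4)c3n2)cc1OC`, keeps the core of compound 1 and changes one group: benzyl in place of benzylcarbamoyl on an amine nitrogen in a ring. Going by the values given here, no measured pair in the set isolates the loss of the carbamoyl portion, so the size of this step rests on expectation alone. The benzyl group is retained, the hydrogen-bond donor and acceptor of the benzylcarbamoyl are not; a moderate weakening is expected, of about the size a 3.3-fold higher number from compound 1 to compound 3 (0.52 log units; beyond the scatter), though a result within the scatter would not surprise. For compound 3 the expected value in this assay is 60 nM, with a range from 12 nM to 400 nM.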

Compound 3, half-maximal inhibitory concentration: 900 nM
For compound 3 the middle estimate is 15-fold (1.18 log units) below the measured one, and the stated range ends below it.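

Among the compounds shown here, on the amine nitrogen in the ring, the benzylcarbamoyl group cannot be traded for benzyl without a large cost in this assay: the change gives a 50-fold higher number from compound 1 to compound 3 (1.70 log units; beyond the scatter) and is the first step read. Both groups carry the same six-membered aromatic ring of carbon only, so keeping that ring on the shared core does not keep the strength of compound 1; the part that leaves with the carbamoyl portion matters at this position, although compound 3 still gives a numerical result of 900 nM and not a limit. Nothing shown gives a cause for the size of this step.

The compounds shown leave open whether the step follows the carbonyl, the amide hydrogen or the length of the link to the aromatic ring, which benzoyl, phenethyl or a benzylcarbamoyl methylated on its amide nitrogen could separate on the same ring nitrogen. They also leave open whether the same step would appear with a group other than the dimethoxyphenyl ring of compound 1 elsewhere on the core, such as a 4-cyanophenyl ring.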